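Methylating the amide nitrogen of a weak inhibitor

The compounds below may be only part of what the source reports. "The series", "measured", "known", "first", "only" and "open" are said of these compounds alone.

Compound 1 `CCOCC1=Cc2ccc(OC)cc2OC1c1cc(OC)c(OC)c(OC)c1` gives 21300 nM in a functional assay for inhibition of nuclear factor NF-kappa-B complex (Homo sapiens); a lower number here means a stronger inhibitor, a higher number a weaker inhibitor.
Compound 2 `CNC(=O)C1=Cc2ccc(OC)cc2OC1c1cc(OC)c(OC)c(OC)c1` reaches only a limit of this assay, > 50000 nM.

Compound 2 therefore sits at the limit of > 50000 nM in this assay, at which 1 of the 2 values shown sits, the weaker end of the two values shown. Among the compounds with values here, the one measured step, an at least 2.3-fold higher number from compound 1 to compound 2 (0.37 log units; beyond the scatter), was at least modest. Compound 3 `COc1ccc2c(c1)OC(c1cc(OC)c(OC)c(OC)c1)C(C(=O)N(C)C)=C2` differs from compound 2 by methyl in place of hydrogen on an amide-type nitrogen. Within the data shown here, no measured step touches the amide nitrogen, so the expectation for compound 3 rests on compound 2 standing at the limit: the estimate is 50000 nM, within 15000 nM to 150000 nM, a step of a number no higher from compound 2 to compound 3 (the limit leaves the size open).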

Compound 3, half-maximal inhibitory concentration: > 50000 nM
Compound 3: a limit, no number; the forecaster's own chance of this, stated with the estimate: 60%; the middle value lies on the limit itself.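

With a methyl on the amide nitrogen, the result in this assay is still a limit and not a number, so this change does not restore a readable value. Replacing ethoxymethyl with dimethylcarbamoyl gives an at least 2.3-fold higher number from compound 1 to compound 3 (0.37 log units; beyond the scatter), so both amides show the same kind of step away from compound 1. The step between compound 2 and compound 3 cannot be read, and the two share one ceiling: the limit of > 50000 nM in this assay, at which 2 of the 3 values shown sit.

On these data alone, whether an amine, a carboxylic acid or a longer ether chain on the double-bonded ring carbon would give a stronger inhibitor than compound 1 remains open.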